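Aminothiophene piperazines: aryl swap on the ring nitrogen

The source may report more compounds than this note shows. Statements on the series, on what has been measured and on what is new or still open speak of the compounds shown alone.

Measured so far:
compound 1 `COc1ccc(N2CCN(Cc3csc(N)c3C(=O)c3ccc(Cl)cc3)CC2)cc1`: -52%
compound 2 `Nc1scc(CN2CCN(c3ccc(Cl)c(C(F)(F)F)c3)CC2)c1C(=O)c1ccc(Cl)cc1`: -60%
compound 3 `Nc1scc(CN2CCN(c3c(F)cccc3F)CC2)c1C(=O)c1ccc(Cl)cc1`: -80%

All three share one core and differ only in the aryl group on the amine nitrogen of the piperazine. In a functional assay on CHO cells with adenosine receptor A1 (Homo sapiens) as the target, read by cAMP accumulation and immunoassay, with a stated time of 6 min, tested at 10 uM (on this read-out higher numbers stand for a weaker effect at the one concentration tested and lower numbers for a stronger effect), compound 2 sits second highest of the three numbers. Its nearest neighbour is compound 1, with the step of a number 8 percentage points lower from compound 1 to compound 2 (within the scatter); the furthest is compound 3, with the step of a number 20 percentage points lower from compound 2 to compound 3 (beyond the scatter). The widest step in the set, a number 28 percentage points lower from compound 1 to compound 3 (beyond the scatter), also runs between two aryl groups at this same nitrogen.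

Compound 4 `Nc1scc(CN2CCN(c3cccc(Cl)c3)CC2)c1C(=O)c1ccc(Cl)cc1` is not yet measured. It differs from compound 2 as follows: 3-chlorophenyl in place of 4-chloro-3-(trifluoromethyl)phenyl on an amine nitrogen in a ring.

The three measured steps all concern the aryl group on this ring nitrogen, and they range from within the scatter to modest. Nothing in the set tells which way a 3-chlorophenyl should move. Given that the step from compound 1 to compound 2 stayed within the scatter and the larger steps were modest, compound 4 is expected to land near compound 2, with the step of a number 5 percentage points higher from compound 2 to compound 4 (within the scatter) estimated as not beyond the scatter. The estimate for compound 4 in this assay is -55%, with a range from -75% to -35%.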

Compound 4, a percentage reported as activity, at one concentration (the size of the read-out at that concentration, not a potency): -77%
Estimate against measurement, compound 4: 22 percentage points above; measured number outside the range, below it.
By their numbers in this assay, from the lowest: compounds 3 and 4 (each within the scatter of the next); then compounds 2 and 1 (each within the scatter of the next).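

In this assay, the step of a number 17 percentage points lower from compound 2 to compound 4 (beyond the scatter) shows that two chlorine-bearing aryl groups at this ring nitrogen need not read alike, with 3-chlorophenyl, which has no trifluoromethyl, parting from 4-chloro-3-(trifluoromethyl)phenyl by a modest margin. The low end of the set no longer rests on 2,6-difluorophenyl alone, as the step of a number 3 percentage points higher from compound 3 to compound 4 (within the scatter) leaves these two aryl groups level, and the step of a number 25 percentage points lower from compound 1 to compound 4 (beyond the scatter) sets 3-chlorophenyl clearly apart from 4-methoxyphenyl. Across these four compounds, the two aryl groups named with a 4-substituent, 4-methoxyphenyl and 4-chloro-3-(trifluoromethyl)phenyl, give the higher numbers, and no compound shown goes against this, though four compounds are a thin basis for it. No supporting data bear on why the numbers fall this way.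

The change from compound 2 to compound 4 removes the trifluoromethyl and also alters where the chlorine is named, so the compounds shown do not separate these two parts of the change. As far as these compounds go, whether the grouping holds for an unsubstituted phenyl or a pyridine ring at this nitrogen stays open, as does how these single-concentration numbers would translate into potency.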